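The source may report more compounds than this note shows. Statements on the series, on what has been measured and on what is new or still open speak of the compounds shown alone.

Compound 1 `COc1cc2nc(N3CCCN(C(=O)N4CCOCC4)CC3)cc(N)c2c(-c2ccccc2)c1OC` gives 8.5 in a physicochemical assay for acid dissociation. For the measured compounds named here, of the three compounds measured so far, this is the highest number. Compound 3 `COc1cc2nc(N3CCc4ncccc4C3)nc(N)c2c(-c2ncccn2)c1OC` gives 6.5 in this assay, a number lower than that of compound 1 by more than the usual scatter, and compound 2 `COc1cc2c(cc1OC)CN(c1nc(N3CCCN(C(=O)N4CC(O)C(O)C4)CC3)nc3cc(OC)c(OC)cc13)CC2` gives 6.2, the number furthest from compound 1, also beyond the scatter.

Compound 4 `COc1cc2nc(N3CCCN(C(=O)N4CCOCC4)CC3)cc(N)c2c(-c2ccc(F)cc2)c1OC` has not yet been measured. It differs from compound 1 in one place: fluoro in place of hydrogen on an aromatic carbon. Going by the values given here, no pair among the measured compounds differs by this single change, so no measured step shows how it moves the acid dissociation constant. The change adds only a single fluorine atom, and the expected step is small, a slight move toward a lower number if any, most likely within the scatter. Compound 4 is therefore expected to give about 8.4, between 8 and 8.8. That estimate means a step of a number 0.10 log units lower from compound 1 to compound 4 (within the scatter).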

Compound 4, acid dissociation constant: 8.5
Estimate against measurement, compound 4: 0.10 log units below, within the range that was stated.
By their numbers in this assay, from the lowest: compounds 2 and 3 (each within the scatter of the next); then compounds 1 and 4 (each within the scatter of the next).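

For the compounds shown here, the step of no change at the digits printed from compound 1 to compound 4 (within the scatter) in this assay is the first direct comparison in this set, since compounds 1, 2 and 3 differ from one another in several places at once. It shows that on this six-membered aromatic ring of carbon only, para to a large group, phenyl can become 4-fluorophenyl without a change in the read-out beyond the scatter. This holds for this one position and this one change on the core of compound 1, and it does not extend to compounds 2 and 3.

The compounds shown leave open whether a different group in the same place, such as an amine, a carboxylic acid or a longer chain, would also leave the number unchanged. No measurement given here explains why fluoro leaves this number unchanged.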